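Capping the free sulfur of compound 3 with acetyl

The source may report more compounds than this note shows. Statements on the series, on what has been measured and on what is new or still open speak of the compounds shown alone.

compound 1 `CCSC(=S)SCC(=O)c1ccc(OC)cc1`: 2510 nM
compound 2 `Cc1ccc(C(=O)CSC(=S)SCc2ccccc2)cc1`: 25100 nM
compound 3 `COc1ccc(C(=O)CS)cc1`: 20000 nM

In a functional assay on HeLa cells (Homo sapiens) for antiproliferative activity, read by resazurin assay (a higher number here means a weaker inhibitor, a lower number a stronger inhibitor), compound 3 gives 20000 nM. That value cannot be told apart from compound 2 at 25100 nM, and it is clearly weaker than compound 1 at 2510 nM.

The next compound, compound 4 `COc1ccc(C(=O)CSC(C)=O)cc1`, keeps the core of compound 3 and changes only the sulfur: acetyl in place of hydrogen on a sulfur. The sulfur that carries a hydrogen in compound 3 carries an acetyl in compound 4.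

Among the measured compounds shown here, only one measured step involves this sulfur, an 8.0-fold higher number from compound 1 to compound 3 (0.90 log units; beyond the scatter), in which a hydrogen took the place of a larger sulfur-bearing group. Potency was lost in that step, so read backwards it suggests that a group on this sulfur can lower the number. Acetyl is a different and smaller group, however, and no measured compound carries it. Only part of that step can reasonably be expected to carry over, and a result within the scatter would be no surprise.

The expected change is a modest fall, a 2.0-fold lower number from compound 3 to compound 4 (0.30 log units; within the scatter). For compound 4 the estimated value in this assay is 10000 nM, with an expected range from 3000 nM to 30000 nM.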

Compound 4, half-maximal inhibitory concentration: 25100 nM
Beside the measured number, compound 4's estimate is 2.5-fold (0.40 log units) below it; low and high end bracket the measured number.
By their numbers in this assay, from the lowest: compound 1; then compounds 3, 2 and 4 (each within the scatter of the next).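

In this assay, putting acetyl in place of hydrogen on this sulfur gives a 1.3-fold higher number from compound 3 to compound 4 (0.10 log units; within the scatter) and so shows no readable effect, which means that covering the free sulfur does not by itself account for the better result of compound 1. The larger sulfur-bearing group of compound 1 still stands apart from acetyl, with a 10-fold higher number from compound 1 to compound 4 (1.00 log units; beyond the scatter) at the same sulfur, so among these compounds the gain goes with that particular group and not with just any group on the sulfur. Nothing measured here explains why these two groups differ.

Going by these compounds, what remains open is which part of the group on compound 1 matters: the ethyl end, the thiocarbonyl or the second sulfur. A plain ethyl directly on the sulfur, or a thiocarbonyl-containing group with an amine in place of the ethylsulfanyl end, would help to separate these parts, and a longer acyl chain such as butanoyl would show whether acetyl is simply too small.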